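This account rests on a few compounds, and the source may have more. Where it says the series, first, only, none or still open, it means among the compounds named here.

Measured compounds:
compound 1, `COc1ccc(/C=C\C(=O)O)c(OCc2cn(-c3ccccc3F)nn2)c1CC=C(C)C`: "not determined" (no result reported) in a functional assay on A549 cells (Homo sapiens) for cytotoxicity, read by MTT assay, with a stated time of 24 h; on this read-out lower numbers stand for stronger inhibition and higher numbers for weaker inhibition
compound 2, `COc1ccc(-n2cc(COc3c(/C=C\C(=O)O)ccc(OC)c3CC=C(C)C)nn2)cc1`: 10200 nM

Going by the values given here, compound 2 therefore stands alone with the only number in this assay, since compound 1 has no value there. Compound 3, `COc1ccc(/C=C\C(=O)O)c(OCc2cn(-c3ccc(C#N)cc3)nn2)c1CC=C(C)C`, is not yet measured. It differs from compound 2 in one place: cyano in place of methoxy on an aromatic carbon. Among the compounds with values here, no pair of measured compounds shows how such a swap shifts this assay, so no direction can be read from the data. The step is expected to be a 1.0-fold lower number from compound 2 to compound 3 (0.01 log units; within the scatter), nothing beyond the usual scatter. Compound 3 is expected near 10000 nM, within a range from 3500 nM to 30000 nM.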

Compound 3, half-maximal inhibitory concentration: 42200 nM
Compound 3: the middle estimate sits 4.2-fold (0.63 log units) below what was measured; the whole stated range lies below it.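

On the aromatic ring carrying these groups, the choice of substituent matters in this assay: swapping methoxy for cyano gives a 4.1-fold higher number from compound 2 to compound 3 (0.62 log units; beyond the scatter) and so a weaker effect on the cells. Both groups have the same heavy-atom count and one hydrogen-bond acceptor, so these counts alone do not account for the shift. Nothing measured here explains why the two groups differ.

Steps involving compound 1 cannot be read, as it has no number. Going by these compounds, how an amine or a chlorine atom at this place would compare remains open.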